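A few compounds are considered here, and "the series" means these few. Any claim that something is new, unique, unknown or untested is made for them only; others in the source may bear on it.

In a functional assay on DU-145 cells (Homo sapiens) for cytotoxicity, read by MTT assay, with a stated time of 24 h (on this read-out lower numbers stand for stronger inhibition and higher numbers for weaker inhibition), compound 2 `COc1ccc(/C=C2\CN(C(=S)SCc3cn(Cc4ccc(F)cc4)nn3)C/C(=C\c3ccc(OC)cc3)C2=O)cc1` gives 74600 nM and stands within the scatter of compound 1 `COc1ccc(/C=C2\CN(C(=S)SCc3cn(Cc4ccccc4F)nn3)C/C(=C\c3ccc(OC)cc3)C2=O)cc1` at 54500 nM while compound 3 `O=C1/C(=C/c2ccccc2F)CN(Cc2cn(Cc3cccc(Cl)c3)nn2)C/C1=C\c1ccccc1F` reads far lower at 4300 nM. Compound 4 `COc1ccc(/C=C2\CN(C(=S)SCc3cn(Cc4cccc(Cl)c4)nn3)C/C(=C\c3ccc(OC)cc3)C2=O)cc1` differs from compound 2 by 3-chlorophenyl in place of 4-fluorophenyl on a saturated chain carbon bound to an aromatic nitrogen. Going by the values given here, the one measured step bearing on this change, a 1.4-fold higher number from compound 1 to compound 2 (0.14 log units; within the scatter), exchanged 2-fluorophenyl for 4-fluorophenyl at that place. Among the compounds with values here, compound 3 also carries 3-chlorobenzyl but differs elsewhere in the molecule, so it offers no direct step. No shift beyond the scatter is expected, and the estimated change is a 1.4-fold lower number from compound 2 to compound 4 (0.16 log units; within the scatter). For compound 4 the expected value is 52000 nM, with an estimated range of 23000 nM to 105000 nM.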

Compound 4, half-maximal inhibitory concentration: > 80000 nM
Compound 4 was reported as a limit; the forecaster's own chance of this, stated with the estimate: 5%; middle value at least 1.5-fold (0.18 log units) from the limit.
By their numbers in this assay, from the lowest: compound 3; then compounds 1 and 2 (each within the scatter of the next). At a limit, above all of these: compound 4.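

Compound 4 is reported only as a limit: the limit of > 80000 nM in this assay, at which 1 of the 4 values shown sits. Its steps, an at least 1.0-fold higher number from compound 2 to compound 4 (0.03 log units; that floor lies within the scatter) and an at least 1.4-fold higher number from compound 1 to compound 4 (0.16 log units; that floor lies within the scatter), are floors, so the true size of the change cannot be read. They do show that 3-chlorophenyl, a chlorine-bearing group at this place, brings no drop in the number on the core shared with the two fluorophenyl compounds. The compounds shown leave open whether an unsubstituted phenyl, an amine or a carboxylic acid on this ring would lower the number. They also leave open what a longer chain would do in place of the saturated chain carbon.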